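Defining the Ring Stereocentres of Compound 2

The source may report more compounds than this note shows. Statements on the series, on what has been measured and on what is new or still open speak of the compounds shown alone.

In an ADME assay on microsomes from liver (Mus musculus) for metabolic stability, read by LC-MS (a higher number here means faster removal of the compound, a lower number slower removal), compound 2 `CC1CCC(NC(=O)c2cc3c(F)cc(F)cc3[nH]2)CC1` gives 866 mL.min-1.g-1. Its nearest neighbour among the measured compounds is compound 1 `C[C@H]1CCCC[C@H]1NC(=O)c1cc2c(F)cc(F)cc2[nH]1`, which gives 660 mL.min-1.g-1, a step of a 1.3-fold higher number from compound 1 to compound 2 (0.12 log units; within the scatter). Its furthest is compound 3 `CC1CCC(NC(=O)c2cc3c(F)cc(Cl)cc3[nH]2)CC1`, which gives 28 mL.min-1.g-1, a step of a 31-fold lower number from compound 2 to compound 3 (1.49 log units; beyond the scatter). Compound 4 `C[C@H]1CC[C@H](NC(=O)c2cc3c(F)cc(F)cc3[nH]2)CC1` differs from compound 2 only in that (the two compounds have the same atoms and bonds; at least one stereo element is drawn with a configuration in one of them and without one in the other: 2 of 2 stereo elements differ; a stereocentre at a saturated ring carbon is drawn without a configuration in compound 2 and r in compound 4; a stereocentre at a saturated ring carbon is drawn without a configuration in compound 2 and r in compound 4). Neither measured step bears directly on this change: one alters the position of the methyl group, the other exchanges a halogen, and both move atoms rather than fix configurations. Within the data shown here, with no step of this kind measured, compound 4 is expected to show no change beyond the scatter in this assay, a 1.0-fold lower number from compound 2 to compound 4 (0.01 log units; within the scatter). Compound 4 is therefore estimated at 850 mL.min-1.g-1, with a range from 420 mL.min-1.g-1 to 1700 mL.min-1.g-1.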

Compound 4, intrinsic clearance in microsomes: 149 mL.min-1.g-1
Beside the measured number, compound 4's estimate is 5.7-fold (0.76 log units) above it; measured number outside the range, below it.
By their numbers in this assay, from the lowest: compound 3; then compound 4; then compounds 1 and 2 (each within the scatter of the next).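

With no atom or bond altered, a 5.8-fold lower number from compound 2 to compound 4 (0.76 log units; beyond the scatter) appears in this assay once both ring stereocentres are defined. The change from 2-methylcyclohexyl to 4-methylcyclohexyl also becomes readable, with a 4.4-fold lower number from compound 1 to compound 4 (0.65 log units; beyond the scatter) where the undefined form had shown a step within the scatter. The gap between compound 2 and compound 4 rests on one structural fact: the fact that one of compounds 2 and 4 is drawn with a defined configuration and the other without, at the place where they differ.

From the compounds shown here alone, it remains open whether defining the same stereocentres in compound 3 would matter as much. Going by these compounds, it is also open whether a 4-ethylcyclohexyl or 4-hydroxycyclohexyl group on the amide nitrogen would respond in the same way.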